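Removing the methyl from the ring nitrogen of compound 3

The source may hold more compounds than are shown below. What is called first, only, known or untested is meant among the compounds shown, and "the series" means these compounds.

Of the compounds shown here, three sharing one core have been measured in an assay on adrenal cortex for inhibition of angiotensinogen (Rattus norvegicus); a lower number here means a stronger inhibitor, a higher number a weaker inhibitor. Compound 1 `CCCCC1Nc2ccccc2C(=O)N1Cc1ccc(-c2ccccc2-c2nn[nH]n2)cc1` gives 14000 nM. Compound 2 `CCCC1Nc2ccc(C(C)C)cc2C(=O)N1Cc1ccc(-c2ccccc2-c2nn[nH]n2)cc1` gives 50 nM. Compound 3 `CCCC1N(Cc2ccc(-c3ccccc3-c3nn[nH]n3)cc2)C(=O)c2ccccc2N1C` gives 540 nM, which places compound 3 second highest of the three numbers; compound 2 sits at a lower number beyond the scatter, and compound 1 at a higher number, also beyond the scatter.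

Compound 4 `CCCC1Nc2ccccc2C(=O)N1Cc1ccc(-c2ccccc2-c2nn[nH]n2)cc1` has not yet been measured. It differs from compound 3 in one spot: hydrogen in place of methyl on a nitrogen on an aromatic ring in a ring. Among the measured compounds shown here, no pair of measured compounds differs by this change alone, so the direction cannot be read from the measured steps. Compound 1, which also carries hydrogen on that nitrogen but a butyl group, gives a high number, while compound 2 carries the same hydrogen with an added isopropyl group and gives a low one. The expected step from compound 3 to compound 4 in this assay is a 3.7-fold higher number from compound 3 to compound 4 (0.57 log units; beyond the scatter), toward a weaker inhibitor. Compound 4 is estimated at 2000 nM, expected between 300 nM and 15000 nM.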

Compound 4, half-maximal inhibitory concentration: 540 nM
Beside the measured number, compound 4's estimate is 3.7-fold (0.57 log units) above it; the measured number falls inside the stated range.
By their numbers in this assay, from the lowest: compound 2; then compounds 3 and 4 (each within the scatter of the next); then compound 1.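

In this assay, hydrogen in place of methyl on the ring nitrogen gives no change at the digits printed from compound 3 to compound 4 (within the scatter), so in this pair the methyl on that nitrogen makes no difference beyond the scatter. The large steps come from the other two places: hydrogen in place of isopropyl on an aromatic carbon gives an 11-fold higher number from compound 2 to compound 4 (1.03 log units; beyond the scatter), and hydrogen in place of methyl on a saturated chain carbon, which turns butyl into propyl, gives a 26-fold lower number from compound 1 to compound 4 (1.41 log units; beyond the scatter). No measurement at hand explains why these two changes matter while the nitrogen change does not.

Still open, from the compounds shown here alone, is whether an ethyl or acetyl group on this nitrogen would leave the number equally unmoved. Also open, going by these compounds, is whether a methoxy group or a chlorine on the aromatic carbon that carries isopropyl in compound 2 would match that compound.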